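This account rests on a few compounds, and the source may have more. Where it says the series, first, only, none or still open, it means among the compounds named here.

Compound 2 `O=C(NCc1ccc(OC(F)(F)F)c(Cl)c1)c1ccc(S(=O)(=O)Nc2nccs2)c(F)c1` gives the lowest of the two numbers in an assay on cells for inhibition of sodium channel protein type 3 subunit alpha (Homo sapiens), read by electrophysiology (on this read-out lower numbers stand for stronger inhibition and higher numbers for weaker inhibition), with 11 nM. For the measured compounds named here, its nearest neighbour, compound 1 `O=C(NCc1ccc(OC(F)(F)F)c(Cl)c1)c1ccc(S(=O)(=O)Nc2nccs2)cc1`, gives 20 nM in this assay, and the only measured step, a 1.8-fold lower number from compound 1 to compound 2 (0.26 log units; within the scatter), lies within the scatter. Compound 3 `O=C(NCc1ccc(OC(F)(F)F)c(Cl)c1)c1ccc(S(=O)(=O)Nc2ncc(F)cn2)c(F)c1` carries a different change: 5-fluoropyrimidin-2-yl in place of 1,3-thiazol-2-yl on a sulfonamide nitrogen. Going by the values given here, no measured step bears on this exchange of one aromatic ring for another on the sulfonamide nitrogen, so there is no basis for expecting a shift beyond the scatter in either direction. Compound 3 is therefore estimated at 20 nM, expected within 5 nM to 80 nM, a step of a 1.8-fold higher number from compound 2 to compound 3 (0.26 log units; within the scatter).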

Compound 3, half-maximal inhibitory concentration: 993 nM
Beside the measured number, compound 3's estimate is 50-fold (1.70 log units) below it; measured number outside the range, above it.
By their numbers in this assay, from the lowest: compounds 2 and 1 (each within the scatter of the next); then compound 3.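

The group on the sulfonamide nitrogen is far from interchangeable in this assay, since 5-fluoropyrimidin-2-yl in place of 1,3-thiazol-2-yl gives a 90-fold higher number from compound 2 to compound 3 (1.96 log units; beyond the scatter), a large loss of inhibition, whereas the earlier fluoro step stayed within the scatter. Nothing available explains this loss. The compounds shown leave open whether the loss follows from the six-membered ring itself or from its fluoro group, as both enter together. They also leave open how a plain pyrimidin-2-yl or a 1,2,4-thiadiazol-5-yl group would fare on this nitrogen.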